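Compound 4 estimated from compound 2

The source may hold more compounds than are shown below. What is called first, only, known or untested is meant among the compounds shown, and "the series" means these compounds.

Measured compounds:
compound 1, `C=CC(=C)CC[C@@H]1[C@@]2(C)CCC[C@](C)(COC(=O)/C=C\c3ccc(O)cc3)[C@@H]2CC[C@@]1(C)O`: 13600 nM
compound 2, `C=CC(=C)CC[C@@H]1[C@@]2(C)CCC[C@](C)(COC(=O)/C=C/c3ccc(O)cc3)[C@@H]2CC[C@@]1(C)O`: 19300 nM
compound 3, `C=C[C@]1(C)O[C@H]1C[C@H]1C(=C)CC[C@@H]2[C@]1(C)CCC[C@]2(C)C(=O)O`: a limit, > 40000 nM

In a functional assay on SW480 cells (Homo sapiens) for cytotoxicity, read by MTT assay, with a stated time of 48 h (a higher number here means a weaker inhibitor, a lower number a stronger inhibitor), compound 1 gives 13600 nM and compound 2 gives 19300 nM. Compound 2 stands highest of the two numbers, with compound 1 as its nearest neighbour at a 1.4-fold higher number from compound 1 to compound 2 (0.15 log units; within the scatter); the two are within the scatter of each other, and they differ only in configuration as drawn (the fact that compounds 1 and 2 differ only in the configuration as drawn). Compound 3 gives only a limit of the assay, > 40000 nM, and that limit is the one at which one of the three values sits (the limit of > 40000 nM in this assay, at which 1 of the 3 values shown sits).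

Compound 4 is `C=CC(=C)CC[C@@H]1[C@@]2(C)CCC[C@](C)(COC(=O)/C=C\c3ccc(O)c(OC)c3)[C@@H]2CC[C@@]1(C)O`. It differs from compound 2 by 2-(4-hydroxy-3-methoxyphenyl)ethenyl in place of 2-(4-hydroxyphenyl)ethenyl on a carbonyl carbon. Going by the values given here, no measured step touches this part of the molecule: the single measured step, a 1.4-fold higher number from compound 1 to compound 2 (0.15 log units; within the scatter), concerns configuration alone and lies within the scatter. There is thus no ground to expect a step beyond the scatter in this assay in either direction. Compound 4 is therefore estimated at a 1.1-fold lower number from compound 2 to compound 4 (0.06 log units; within the scatter), giving an expected value of 17000 nM with a range from 7000 nM to 40000 nM.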

Compound 4, half-maximal inhibitory concentration: 17600 nM
Compound 4: middle estimate off by 1.0-fold (0.02 log units), on the low side, and the stated range covers the measured number.
By their numbers in this assay, from the lowest: compounds 1, 4 and 2 (each within the scatter of the next). At a limit, above all of these: compound 3.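

The earlier compounds shown here 1 and 2 varied this part only in the configuration of a double bond; compound 4 alters the aromatic ring itself, with methoxy in place of hydrogen on an aromatic carbon, and in this assay this gives a 1.3-fold higher number from compound 1 to compound 4 (0.11 log units; within the scatter). Set against the compound with the double bond drawn the other way, the result is a 1.1-fold lower number from compound 2 to compound 4 (0.04 log units; within the scatter), so all three numbers remain within the scatter of one another. Nothing given here bears on why this is so.

From the compounds shown here alone, whether an amine, a carboxylic acid or a longer chain in place of the methoxy would give a step beyond the scatter stays open. Compound 3 has only a limit in this assay, > 40000 nM. It differs from the others in more than one place, and the data do not separate these places from one another.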